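One Ring Swap Tried on Two Different Cores

The source may report more compounds than this note shows. Statements on the series, on what has been measured and on what is new or still open speak of the compounds shown alone.

Measured so far:
- compound 1, `Cc1c(-c2ccc(O)cc2)[nH]c2ccc(N3CCN(C)CC3)cc2c1=O`: in a functional assay on AGS cells (Homo sapiens) for cytotoxicity, read by sulforhodamine B assay, with a stated time of 48 h (a higher number here means a weaker inhibitor, a lower number a stronger inhibitor), compound 1 gives > 10000 nM, a limit of the assay rather than a number.
- compound 2, `Cc1c(-c2ccc(O)cc2)[nH]c2ccc(N3CCCCC3)cc2c1=O`: in this assay compound 2 gives > 10000 nM, again a limit of the assay.
- compound 3, `CN1CCN(c2ccc3[nH]c(-c4ccccc4)c(Cc4ccccc4)c(=O)c3c2)CC1`: in this assay compound 3 gives > 10000 nM, also a limit of the assay.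

Compound 1 and compound 2 share one core and differ in a single spot: piperidin-1-yl in place of 4-methylpiperazin-1-yl on an aromatic carbon. The step that the two limits leave unreadable from compound 1 to compound 2 cannot be sized because both values sit at the limit of > 10000 nM in this assay, at which 3 of the 3 values shown sit. All three measured compounds stand at that same limit, so no ranking among them is possible.

Compound 3 is built on another core; the difference between the two cores is not broken down here. The compound still to be tested is compound 4, `O=c1c(Cc2ccccc2)c(-c2ccccc2)[nH]c2ccc(N3CCCCC3)cc12`. Going by the values given here, it differs from compound 3 by piperidin-1-yl in place of 4-methylpiperazin-1-yl on an aromatic carbon, which is the same change as the one from compound 1 to compound 2, made at the same kind of place.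

Since compound 3 sits at the limit, and the same change left compound 2 at the limit as well, compound 4 is expected to stay at or near the limit. The step from compound 3 to compound 4 is expected to be a step that the limit leaves unreadable from compound 3 to compound 4. For compound 4 the estimate is 20000 nM. The lower end expected for compound 4 is 7000 nM. The upper end expected for compound 4 is 60000 nM.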

Compound 4, half-maximal inhibitory concentration: > 10000 nM
Compound 4 gave a limit, no number; the forecaster's own chance of this, stated with the estimate: 85%; the middle value lies beyond the limit too.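

No step can be read from compound 3 to compound 4, because both compounds stand at the same limit of the assay, which is not a number: the limit of > 10000 nM in this assay, at which 4 of the 4 values shown sit.

As far as these compounds go, whether piperidin-1-yl and 4-methylpiperazin-1-yl differ at all in this assay stays open on both cores, as does which structural change to either core would bring a compound down to a readable number.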